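Taking 2-chloro-6-fluorophenyl away from compound 3

The compounds below may be only part of what the source reports. "The series", "measured", "known", "first", "only" and "open" are said of these compounds alone.

In a functional assay on the whole organism with Rattus norvegicus as the target (on this read-out higher numbers stand for an effect only at larger amounts of compound and lower numbers for an effect already at smaller amounts), compound 3 `CCOCCOC(=O)C(=O)Nc1nc(-c2cc(-c3c(F)cccc3Cl)no2)cs1` gives 1.1 mg/kg as the lowest of three numbers, while compound 1 `CCOCCOC(=O)C(=O)Nc1nc(-c2cc(OC)no2)cs1` gives 3 mg/kg and compound 2 `CCOCCOC(=O)C(=O)Nc1nc(-c2cc(OCc3ccccc3)no2)cs1` gives 3.7 mg/kg within the scatter of each other. Compound 4 `CCOCCOC(=O)C(=O)Nc1nc(-c2cc(C(=O)OCC)no2)cs1` carries ethoxycarbonyl in place of 2-chloro-6-fluorophenyl on an aromatic carbon. Going by the values given here, no measured compound carries ethoxycarbonyl. The closest evidence is a 2.7-fold lower number from compound 1 to compound 3 (0.44 log units; beyond the scatter) and a 3.4-fold lower number from compound 2 to compound 3 (0.53 log units; beyond the scatter) as two modest steps that brought 2-chloro-6-fluorophenyl in. Its removal is therefore expected to give a modest step to a higher number in this assay, back to the level of compound 1 and compound 2. The estimated change is a 2.7-fold higher number from compound 3 to compound 4 (0.44 log units; beyond the scatter). For compound 4 the estimated value is 3 mg/kg (expected range 1.2 mg/kg to 8 mg/kg).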

Compound 4, dose for half-maximal effect: 0.08 mg/kg
Estimate against measurement, compound 4: 38-fold (1.57 log units) above; the whole stated range lies above it.
By their numbers in this assay, from the lowest: compound 4; then compound 3; then compounds 1 and 2 (each within the scatter of the next).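

Going by these compounds alone, at this aromatic carbon next to the ring nitrogen, the earlier compounds showed only modest steps in this assay, whereas ethoxycarbonyl in place of 2-chloro-6-fluorophenyl gives a large one (a 14-fold lower number from compound 3 to compound 4 (1.14 log units; beyond the scatter)). The change is also large against benzyloxy (a 46-fold lower number from compound 2 to compound 4 (1.67 log units; beyond the scatter)) and methoxy (a 38-fold lower number from compound 1 to compound 4 (1.57 log units; beyond the scatter)), so the lowest number here comes with a carbonyl-bearing group that has no ring. The data shown offer no measured basis for explaining these steps. On these data alone, it remains open whether the ethyl ester is specifically required, or whether a carboxylic acid, a primary amide or a ketone at this position would give a similar number in this assay.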